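The source may hold more compounds than are shown below. What is called first, only, known or untested is meant among the compounds shown, and "the series" means these compounds.

In a functional assay on HeLa cells (Homo sapiens) for antiproliferative activity, read by MTT assay, with a stated time of 72 h (a higher number here means a weaker inhibitor, a lower number a stronger inhibitor), compound 1 `O=C1O/C(=C\Cn2cnc3cc[nH]c3c2=O)C(OCc2ccccc2)=C1OCc1ccccc1` gives 27000 nM and compound 2 `O=C1O/C(=C\Cn2cnc3ncc(Br)c-3c2)C(OCc2ccccc2)=C1OCc1ccccc1` gives 17000 nM. These two values lie within the scatter of each other, so compound 2 stands level with compound 1 and neither can be ranked above the other. Compound 3 `O=C1O/C(=C\Cn2cnc3c(Cl)c(F)nc(F)c32)C(OCc2ccccc2)=C1OCc1ccccc1` has not yet been measured. It differs from compound 2 on a saturated chain carbon bound to a double-bonded chain carbon: a group of 12 heavy atoms (6 carbon, 3 nitrogen, 2 fluorine, 1 chlorine; one five-membered aromatic ring with 2 hetero atoms, one six-membered aromatic ring with 1 hetero atom) in place of a group of 10 heavy atoms (6 carbon, 3 nitrogen, 1 bromine; one five-membered aromatic ring with 1 hetero atom, one six-membered aromatic ring with 2 hetero atoms), on a saturated chain carbon bound to a double-bonded chain carbon. The group that enters carries 2 fluorine and 1 chlorine, and its hetero atoms are shared differently between its two aromatic rings. Going by the values given here, only one measured step bears on this change, as it also exchanges the group at that place: a 1.6-fold lower number from compound 1 to compound 2 (0.20 log units; within the scatter). Among the compounds with values here, that exchange left the value within the scatter, but it is a single step, and no measured compound carries fluorine or chlorine. No step beyond the scatter is therefore expected in this assay, though the uncertainty is wide. The estimated change is a 1.4-fold lower number from compound 2 to compound 3 (0.15 log units; within the scatter). Compound 3 is expected at about 12000 nM, with an estimated range from 4000 nM to 30000 nM.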

Compound 3, half-maximal inhibitory concentration: > 100000 nM
Compound 3: no number, only a limit; the forecaster's own chance of this, stated with the estimate: 10%; middle value at least 8.3-fold (0.92 log units) away from the limit.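

Going by these compounds alone, until this result, exchanging the group at this place, on a saturated chain carbon bound to a double-bonded chain carbon, had moved nothing beyond the scatter in this assay, yet the group carrying 2 fluorine and 1 chlorine brings an at least 5.8-fold higher number from compound 2 to compound 3 (0.76 log units; beyond the scatter). Set against the group of compound 1, the same group brings an at least 3.7-fold higher number from compound 1 to compound 3 (0.56 log units; beyond the scatter), so the number does depend on which group sits at this place, and the earlier pair could not show that. The value of compound 3 is a limit and not a number: the limit of > 100000 nM in this assay, at which 1 of the 3 values shown sits.

The entering group differs from both others at once in its halogens and in how its hetero atoms are shared between its two aromatic rings, so the compounds shown cannot separate the part played by the fluorine, the chlorine or the ring arrangement. They also leave open how the same ring arrangement would read with a methyl group or an amine in place of the halogens, and whether any group at this place would give a value clearly lower than those of compound 1 and compound 2.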